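The compounds below may be only part of what the source reports. "The series", "measured", "known", "first", "only" and "open" are said of these compounds alone.

Of the compounds shown here, three from this series have been measured in an ADME assay for permeability, using PAMPA, with a stated time of 30 min, at pH 7.4; a lower number here means that the compound crosses the layer more slowly, a higher number that the compound crosses the layer faster. Compound 1 `COc1cccc(CNCCCNc2ccnc3cc(Oc4ccccc4)ccc23)c1O` gives 317 10^-6 cm/s. Within the data shown here, compound 3 `COc1cccc(CNCCCNc2ccnc3cc(Cc4cccc(C(F)(F)F)c4)ccc23)c1O` gives 23 10^-6 cm/s, and the single change that separates them, 3-(trifluoromethyl)benzyl in place of phenoxy on an aromatic carbon, is accompanied by a 14-fold lower number from compound 1 to compound 3 (1.14 log units; beyond the scatter). Compound 2 `Cc1cc(C)cc(Cc2ccc3c(NCCCNCc4ccco4)ccnc3c2)c1` gives 23 10^-6 cm/s in this assay , so compound 2 stands level with compound 3 at the digits shown, the two together at the low end of the three numbers, while compound 1 lies well above both.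

Compound 4 `Clc1ccc(Oc2ccc3c(NCCCNCc4ccco4)ccnc3c2)cc1` is the next compound to be measured, and it differs from compound 2 in one place: 4-chlorophenoxy in place of 3,5-dimethylbenzyl on an aromatic carbon. Among the measured compounds shown here, the only measured step that bears on this change is the one from compound 1 to compound 3, in which a benzyl group replaced a phenoxy group at the same position of the shared core and the number fell sharply. The change from compound 2 to compound 4 runs in the opposite direction, benzyl out and an aryloxy group in, though the aryloxy group here carries a chlorine. An increase is therefore expected in this assay , plausibly somewhat smaller than the step between compound 1 and compound 3, so compound 4 is expected to give about 120 10^-6 cm/s, with a range from 40 10^-6 cm/s to 350 10^-6 cm/s, which corresponds to an expected step of a 5.2-fold higher number from compound 2 to compound 4 (0.72 log units; beyond the scatter).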

Compound 4, apparent permeability: 317 10^-6 cm/s
Beside the measured number, compound 4's estimate is 2.6-fold (0.42 log units) below it; measured number inside the range.
By their numbers in this assay, from the lowest: compounds 2 and 3 (each within the scatter of the next); then compounds 1 and 4 (each within the scatter of the next).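

In this assay, putting 4-chlorophenoxy in place of 3,5-dimethylbenzyl on this aromatic carbon goes with a 14-fold higher number from compound 2 to compound 4 (1.14 log units; beyond the scatter), so the number at this position can move sharply upward as well as downward, as in a 14-fold lower number from compound 1 to compound 3 (1.14 log units; beyond the scatter). Across these two pairs, which differ in the rest of the molecule and in the substituents on the aromatic ring, the compound carrying the oxygen-linked aromatic ring has the higher number, and neither pair goes against this, although two pairs are a narrow basis for any pattern. Nothing shown here gives a reason for the size or direction of either step.

The compounds shown leave open how much of the rise from 3,5-dimethylbenzyl to 4-chlorophenoxy goes with the oxygen link and how much with the exchange of two methyl groups for one chlorine, as both changes occur together in this step. A 4-chlorobenzyl group on the same carbon, with the rest of the molecule kept as it is, would separate these two contributions in this assay.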